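This account rests on a few compounds, and the source may have more. Where it says the series, first, only, none or still open, it means among the compounds named here.

Compound 1 `C=C[C@@](C)(/C=C/c1ccc(O)cc1)CCCO`: > 26000 nM
Compound 2 `C=C[C@@](C)(/C=C/c1ccc(O)cc1)CC/C=C/C(=O)OCC`: > 26000 nM
Compound 3 `C=C[C@@](C)(/C=C/c1ccc(O)cc1)CC/C=C/C#N`: > 26000 nM

Each entry above is a limit and not a number. In a functional assay on Raji cells (Homo sapiens) for cytotoxicity, with a stated time of 72 h (a higher number here means that more compound is needed for the effect, a lower number that less compound is needed), compound 3 gives > 26000 nM, which is a limit. It therefore stands where the other two compounds stand, with the limit of > 26000 nM in this assay, at which 3 of the 3 values shown sit.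

Compound 4 `C=C[C@@](C)(/C=C/c1ccc(O)cc1)CC/C=C(C)/C=N/N` differs from compound 3 in one place: a group of 6 heavy atoms (4 carbon, 2 nitrogen; no ring) in place of a group of 4 heavy atoms (3 carbon, 1 nitrogen; no ring), on a saturated chain carbon, three bonds along the chain from two double-bonded chain carbons.

For the measured compounds named here, three measured steps bear on this change: a step that the two limits leave unreadable from compound 1 to compound 3, a step that the two limits leave unreadable from compound 2 to compound 3 and a step that the two limits leave unreadable from compound 1 to compound 2. None of them has a readable size, so they point in no direction, and no step beyond the usual scatter can be expected from them. Compound 4 is expected to stay near the same limit, and it may well report only a limit again.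

The estimated step is a number no higher from compound 3 to compound 4 (the limit leaves the size open). For compound 4 the expected value is 26000 nM, with an estimated range from 10000 nM to 50000 nM.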

Compound 4, half-maximal effective concentration: > 26000 nM
Compound 4 ended at the assay's limit; the forecaster's own chance of this, stated with the estimate: 80%; the middle value lies on the limit itself.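

Compound 4 gives only a limit, as do compound 1, compound 2 and compound 3, so no step among these four compounds can be read in this assay: the limit of > 26000 nM in this assay, at which 4 of the 4 values shown sit.

The compounds shown leave open how far apart these four compounds truly lie, and whether any change to the shared core would give a measurable value.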